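Ring-carbon substituent variation in an antagonist series

A few compounds are considered here, and "the series" means these few. Any claim that something is new, unique, unknown or untested is made for them only; others in the source may bear on it.

Values in a functional assay for antagonist activity at 5-hydroxytryptamine receptor 4 (Rattus norvegicus) (on this read-out higher numbers stand for higher potency (the scale is a negative logarithm) and lower numbers for lower potency), for the two compounds measured so far:
Compound 1, `COc1cc(COc2cc(N)c(Cl)cc2C(=O)CCCCN2CCC(C)CC2)cc(OC)c1`, gives 8.3.
Compound 2, `COc1cc(COc2cc(N)c(Cl)cc2C(=O)CCCCN2CCC(C(N)=O)CC2)cc(OC)c1`, gives 8.4.

Within the data shown here, compound 2 holds the larger of the two numbers, but the only comparison available, a number 0.10 log units higher from compound 1 to compound 2 (within the scatter), lies within the scatter, so the two compounds are not distinguished in this assay.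

Compound 3, `COc1cc(COc2cc(N)c(Cl)cc2C(=O)CCCCN2CCC(CCNS(C)(=O)=O)CC2)cc(OC)c1`, has not been measured. It differs from compound 2 in one place: 2-(methanesulfonamido)ethyl in place of carbamoyl on a saturated ring carbon. Among the measured compounds shown here, the single measured step at this ring carbon, a number 0.10 log units higher from compound 1 to compound 2 (within the scatter), was within the scatter, which suggests that this position tolerates exchange of a small group without a visible shift. For the measured compounds named here, the group entering in compound 3 is considerably larger than anything yet tested there, and no measured step covers it, so the expectation rests on the one small step alone. No step beyond the scatter is expected in this assay.

Compound 3 is therefore estimated at 8.3, with a range from 7.6 to 9. The step of a number 0.10 log units lower from compound 2 to compound 3 (within the scatter) is the expected one.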

Compound 3, negative logarithm of the antagonist equilibrium constant: 8.1
For compound 3 the middle estimate is 0.20 log units above the measured one; low and high end bracket the measured number.
By their numbers in this assay, from the lowest: compounds 3, 1 and 2 (each within the scatter of the next).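

With this assay as the read-out, the two new comparisons are a number 0.30 log units lower from compound 2 to compound 3 (within the scatter) and a number 0.20 log units lower from compound 1 to compound 3 (within the scatter) and neither separates the compounds. The earlier pair covered only methyl and carbamoyl, whereas the ring carbon three ring bonds from the ring nitrogen now also accepts 2-(methanesulfonamido)ethyl, with 7 heavy atoms against 3 for carbamoyl, without a step beyond the scatter. Nothing in the data on hand accounts for this tolerance.

Going by these compounds, whether it extends to a primary amine, a carboxylic acid or a longer chain at this ring carbon remains open, and so does the outcome with a hydrogen alone there. On these data alone, the three compounds also share one read-out, so any difference between them elsewhere remains unknown.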